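A few compounds are considered here, and "the series" means these few. Any claim that something is new, unique, unknown or untested is made for them only; others in the source may bear on it.

Compound 3 `CN(C)CCCCOC(=O)Nc1ccc(Cn2nc(-c3ccccc3)c3ccccc3c2=O)cc1` has been tested in an ADME assay on Huh-7 cells (Homo sapiens) for cytotoxicity, read by MTT assay, with a stated time of 48 h (a lower number here means that less compound is tolerated, a higher number that more compound is tolerated), where compound 3 gives 16000 nM. Compound 2 `CN(C)CCCCN(C(=O)O)c1ccc(Cn2nc(-c3ccc(F)cc3)c3ccccc3c2=O)cc1` gives 19000 nM in this assay, and the two numbers lie within the usual scatter of one another. Compound 1 `Nc1ccc(CN2N=C(c3ccc(F)cc3)C3C=CC=CC3C2=O)cc1` gives > 80000 nM, which is a limit of the assay rather than a number. Compound 4 `CN(C)CCCCOC(=O)Nc1ccc(Cn2nc(-c3ccccc3C(F)(F)F)c3ccccc3c2=O)cc1` has not yet been measured. It differs from compound 3 in one place: trifluoromethyl in place of hydrogen on an aromatic carbon. Among the measured compounds shown here, no measured pair shows this same change, so the expectation rests on the values of compound 3 and compound 2. In this assay the step of a 1.3-fold lower number from compound 3 to compound 4 (0.12 log units; within the scatter) is expected to be small, a slight lowering unlikely to exceed the scatter. Compound 4 is estimated at 12000 nM, within a range from 5000 nM to 30000 nM.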

Compound 4, half-maximal cytotoxic concentration: 35700 nM
Beside the measured number, compound 4's estimate is 3.0-fold (0.47 log units) below it, outside the stated range (above it).
By their numbers in this assay, from the lowest: compounds 3, 2 and 4 (each within the scatter of the next, the first and the last beyond it). At a limit, above all of these: compound 1.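

In this assay, trifluoromethyl in place of hydrogen on this aromatic carbon, ortho to a large group, gives a 2.2-fold higher number from compound 3 to compound 4 (0.35 log units; beyond the scatter), so more compound is tolerated after this change. Among the compounds shown here, the earlier compounds offered no pair differing in one place, so this is the first reading of any change at this position. Nothing among the values shown accounts for this step. Still open, going by these compounds, is whether a single fluorine, a methoxy group or an amine on this same carbon would move the number the same way. On these data alone, whether trifluoromethyl on another carbon of this ring would do so is also open.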